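Methylating the Ring Nitrogen of a Serotonin Receptor Agonist

The source may report more compounds than this note shows. Statements on the series, on what has been measured and on what is new or still open speak of the compounds shown alone.

Among the compounds with values here, compound 2 `COc1ccccc1-c1cc(C2CCNC2)ccc1Cl` is the only compound here with a number: in a functional assay on HEK293 cells for agonist activity at 5-hydroxytryptamine receptor 7 (Homo sapiens), read by a luciferase reporter and beta-arrestin recruitment, with a stated time of 22 h (a lower number here means a smaller maximal response, a higher number a larger maximal response), compound 2 reaches 54%. Compound 1 `CCCN(CCC)Cc1ccc(Cl)c(-c2ccccc2OC)c1` is recorded in this assay as "not active" (no number reported), without a number. Compound 3 `COc1ccccc1-c1cc(C2CCN(C)C2)ccc1Cl` differs from compound 2 only by methyl in place of hydrogen on an amine nitrogen in a ring. Within the data shown here, no step between two measured compounds is available to guide this change, so from compound 2 to compound 3 a shift no larger than the usual scatter of this assay is expected. Compound 3 is therefore estimated to give 52%, between 28% and 78%. The expected step of a number 2 percentage points lower from compound 2 to compound 3 (within the scatter) stays within the scatter.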

Compound 3, largest response reached (Emax), in percent of the reference or control that the assay uses: 51%
Estimate against measurement, compound 3: 1 percentage points above; the range from low to high includes it.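

In this assay, placing methyl instead of hydrogen on the amine nitrogen in the ring gives a step of a number 3 percentage points lower from compound 2 to compound 3 (within the scatter), so the two compounds cannot be told apart. The hydrogen on this nitrogen is therefore not required for a measurable maximal response, at least when methyl replaces it in compound 3. No measurement shown explains this result. Still open, going by these compounds, is whether the response would hold with an ethyl or benzyl group on this nitrogen, and whether an acetyl group there would give the same outcome.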